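Chain length and cytotoxicity in a quinazoline-free account of three thioethers

The source may report more compounds than this note shows. Statements on the series, on what has been measured and on what is new or still open speak of the compounds shown alone.

Measured in a functional assay on MDA-MB-231 cells (Homo sapiens) for cytotoxicity, read by MTT assay, with a stated time of 72 h; a lower number here means a stronger inhibitor, a higher number a weaker inhibitor:
Compound 1, `CCCCCCNc1nc(SCc2ccc(C(F)(F)F)cc2)nc2ccccc12`, gives 20200 nM.
Compound 2, `CCCCCCCCNc1nc(SCc2ccc(C(F)(F)F)cc2)nc2ccccc12`, gives 22300 nM.
Compound 3, `CCCCCCCCCCCCNc1nc(SCc2ccc(C(F)(F)F)cc2)nc2ccccc12`, gives only a limit, > 50000 nM.

Compound 3 thus stands at the limit of this assay rather than at a number, as the limit of > 50000 nM in this assay, at which 1 of the 3 values shown sits, records. Compound 4, `CCCCCCCCCCCCCCNc1nc(SCc2ccc(C(F)(F)F)cc2)nc2ccccc12`, differs from compound 3 by ethyl in place of hydrogen on a saturated chain carbon, ten or more bonds along the chain from a nitrogen on an aromatic ring. Among the compounds with values here, the steps that bear on this change all lengthen the same chain: a 1.1-fold higher number from compound 1 to compound 2 (0.04 log units; within the scatter), an at least 2.4-fold higher number from compound 1 to compound 3 (0.39 log units; beyond the scatter) and an at least 2.2-fold higher number from compound 2 to compound 3 (0.35 log units; beyond the scatter). The first of these lies within the scatter, the other two reach beyond it and both run toward weaker inhibition, and compound 3 already sits at the limit. A further lengthening of the chain is therefore expected to leave compound 4 at or beyond that limit, with the step from compound 3 estimated as a step that the limit leaves unreadable from compound 3 to compound 4. Compound 4 is expected to give about 80000 nM in this assay, within a range from 40000 nM to 200000 nM, most likely reported again as a limit.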

Compound 4, half-maximal inhibitory concentration: > 50000 nM
Compound 4: a limit, no number (the forecaster's own chance of this, stated with the estimate: 85%); the middle value is on the limit's open side.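

In this assay compound 4 gives > 50000 nM, a limit and not a number, so adding ethyl to the chain of compound 3 brings back no readable activity, and the step between these two cannot be read. Against the shorter chains, the result is an at least 2.2-fold higher number from compound 2 to compound 4 (0.35 log units; beyond the scatter) and an at least 2.4-fold higher number from compound 1 to compound 4 (0.39 log units; beyond the scatter), so the weaker side of this series now holds two compounds rather than one. Compound 3 is therefore no lone reading, but the assay bounds what can be said at this end of the series: the limit of > 50000 nM in this assay, at which 2 of the 4 values shown sit.

From the compounds shown here alone, how far compound 3 and compound 4 each lie past the limit stays open, and with it whether the added ethyl changes anything at all. Also open, going by these compounds, is whether a chain ending in an amine or a carboxylic acid would return a readable value.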